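This account rests on a few compounds, and the source may have more. Where it says the series, first, only, none or still open, it means among the compounds named here.

Measured so far in a functional assay on the whole organism for inhibition, with Canis familiaris (Canis lupus familiaris) as the target; a higher number here means that more compound is needed for the effect, a lower number that less compound is needed:

- compound 1 `CCN1CCCC1CNC(=O)c1cc(NS(=O)(=O)N(C)C)c(C)cc1OC`; compound 1 gives 0.05 mg/kg
- compound 2 `CCN1CCCC1CNC(=O)c1cc(NS(=O)(=O)N(C)C)c(Cl)cc1OC`; compound 2 gives 0.05 mg/kg
- compound 3 `CCN1CCCC1CNC(=O)c1cc(NS(C)(=O)=O)c(C)cc1OC`; compound 3 gives 1 mg/kg

Compound 4 `CCN1CCCC1CNC(=O)c1cc(NS(C)(=O)=O)c(Cl)cc1OC` awaits measurement in this assay.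

The two cores differ as methyl in place of dimethylamino on a sulfonyl sulfur; that step is a 20-fold higher number from compound 1 to compound 3 (1.30 log units; beyond the scatter).

The change toward compound 4 is chloro in place of methyl on an aromatic carbon. The same kind of change, (chloro in place of methyl on an aromatic carbon), gave no change at the digits printed from compound 1 to compound 2 (within the scatter). The surroundings are not identical: in compound 1 the site is ortho to a (dimethylsulfamoyl)amino group, in compound 3 ortho to a methanesulfonamido group, so this is the same kind of change, not the same change.

Resting on no change at the digits printed from compound 1 to compound 2 (within the scatter), the expected step is no change at the digits printed from compound 3 to compound 4 (within the scatter). Compound 4 is thus estimated at 1 mg/kg, expected between 0.4 mg/kg and 2.5 mg/kg.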

Compound 4, dose for half-maximal effect: 0.1 mg/kg
For compound 4 the middle estimate is 10-fold (1.00 log units) above the measured one, and the stated range ends above it.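

In this assay, chloro in place of methyl on an aromatic carbon gives a 10-fold lower number from compound 3 to compound 4 (1.00 log units; beyond the scatter), so this change does not carry over unaltered from the core of compound 1 to the core of compound 3: the same change on two cores in this assay, no change at the digits printed (within the scatter) from compound 1 to compound 2 and a 10-fold lower number (1.00 log units; beyond the scatter) from compound 3 to compound 4, 10-fold (1.00 log units) apart, beyond the scatter of two such steps. Methyl in place of dimethylamino on a sulfonyl sulfur now gives only a 2.0-fold higher number from compound 2 to compound 4 (0.30 log units; within the scatter), so the two changes do not add independently across these four compounds: the same change on two cores in this assay, a 20-fold higher number (1.30 log units; beyond the scatter) from compound 1 to compound 3 and a 2.0-fold higher number (0.30 log units; within the scatter) from compound 2 to compound 4, 10-fold (1.00 log units) apart, beyond the scatter of two such steps. This shows that a step read on one core is a poor guide to the same step on the other, but not why the steps differ or how far this extends beyond these compounds.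

Only methyl and chloro appear on the aromatic carbon, and only methyl and dimethylamino on the sulfonyl sulfur. As far as these compounds go, whether bromo at the former or a longer chain such as ethyl at the latter shows the same dependence stays open.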